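Swapping the Sulfur-Linked Tetrazole for a Bromophenyl Sulfonamide

The compounds below may be only part of what the source reports. "The series", "measured", "known", "first", "only" and "open" are said of these compounds alone.

Measured in a functional assay on HepG2 cells (Homo sapiens) for antiproliferative activity, read by MTT assay, with a stated time of 48 h; a higher number here means a weaker inhibitor, a lower number a stronger inhibitor:
Compound 1 `COc1ccc(CN(C(=O)Cn2cc(CSc3nc4ccccc4s3)nn2)c2cc(OC)c(OC)c(OC)c2)cc1`: 49200 nM
Compound 2 `COc1ccc(CN(C(=O)Cn2cc(CSc3nc4ccccc4o3)nn2)c2cc(OC)c(OC)c(OC)c2)cc1`: 15600 nM
Compound 3 `COc1ccc(CN(C(=O)Cn2cc(CSc3nnnn3C)nn2)c2cc(OC)c(OC)c(OC)c2)cc1`: 28300 nM

Compound 3 stands within the scatter of both other compounds, as shown by a 1.7-fold lower number from compound 1 to compound 3 (0.24 log units; within the scatter) and by a 1.8-fold higher number from compound 2 to compound 3 (0.26 log units; within the scatter). Among the measured compounds shown here, the only step beyond the scatter is the modest one, a 3.2-fold lower number from compound 1 to compound 2 (0.50 log units; beyond the scatter).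

Compound 4 `COc1ccc(CN(C(=O)Cn2cc(CNS(=O)(=O)c3ccc(Br)cc3)nn2)c2cc(OC)c(OC)c(OC)c2)cc1` is the next to be tested in this assay. It carries ((4-bromophenyl)sulfonyl)amino in place of (1-methyl-1H-tetrazol-5-yl)sulfanyl on a saturated chain carbon bound to an aromatic carbon.

All three measured steps exchange one group on a sulfur and keep that sulfur, whereas this change removes it. None of them tests the new group, so they bear on it only indirectly. They show that three different groups on the sulfur gave values no further apart than compound 2 at 15600 nM and compound 1 at 49200 nM. The data give no direction for the new group, so no step beyond the scatter is firmly expected, although the uncertainty is wide. The expected step is a 1.1-fold lower number from compound 3 to compound 4 (0.05 log units; within the scatter). Compound 4 is estimated at 25000 nM, with an expected range from 8000 nM to 80000 nM.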

Compound 4, half-maximal inhibitory concentration: 7370 nM
Compound 4: the middle estimate sits 3.4-fold (0.53 log units) above what was measured; measured number outside the range, below it.
By their numbers in this assay, from the lowest: compound 4; then compounds 2, 3 and 1 (each within the scatter of the next, the first and the last beyond it).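

In this assay this is the first change that removes the sulfur instead of exchanging the group on it, and ((4-bromophenyl)sulfonyl)amino on a saturated chain carbon bound to an aromatic carbon gives a lower number than every sulfur-linked group shown: a 3.8-fold lower number from compound 3 to compound 4 (0.58 log units; beyond the scatter) and a 2.1-fold lower number from compound 2 to compound 4 (0.33 log units; beyond the scatter) and also a 6.7-fold lower number from compound 1 to compound 4 (0.82 log units; beyond the scatter) all lie beyond the scatter. The earlier compounds shown here showed only that the position accepts three different groups on a sulfur, whereas compound 4 shows that the sulfur-linked arrangement is not needed for activity here and that a group with a six-membered aromatic ring of carbon only and a hydrogen-bond donor can stand in its place with a modest gain. No measurement given here accounts for this gain. 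

The compounds shown leave open which part of the entering group carries the step, as the bromine, the phenyl ring, the sulfonyl and the amide-like hydrogen all enter together. A plain phenyl or a 4-chlorophenyl on the sulfonyl, a carbonyl in place of the sulfonyl, or a methyl on the nitrogen would each separate one of these parts.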